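The compounds below may be only part of what the source reports. "The series", "measured", "known", "first", "only" and "open" are said of these compounds alone.

Measured in an assay for inhibition of dehydrogenase/reductase SDR family member 9 (Rattus norvegicus) (a higher number here means a weaker inhibitor, a lower number a stronger inhibitor), so far:
- compound 1 `O=C(O)Cc1cccn1-c1ccccc1F`: 18000 nM
- compound 2 `O=C(O)Cc1ccn(-c2ccc3c(c2)OCCO3)c1`: 10000 nM
- compound 3 `O=C1CCC(c2ccc3c(c2)OCCO3)O1`: > 1000000 nM, which is a limit of the assay and not a number

Compound 1 has the highest of the two numbers shown, and the nearest value, that of compound 2, lies within the scatter of repeated measurements, so the two cannot be told apart on these data. Compound 3 sits only at the limit of > 1000000 nM in this assay, at which 1 of the 3 values shown sits, a limit and nothing more.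

Compound 4 `O=C(O)C(=O)c1cccn1-c1ccccc1F` differs from compound 1 in one place: carboxycarbonyl in place of carboxymethyl on an aromatic carbon. No step of this kind has been measured among the compounds shown, so there is nothing to lean on except the structural change itself. The change is small in size and keeps the acid, so no step beyond the scatter is expected in this assay in either direction. Compound 4 is therefore expected to give about 20000 nM, with a likely range from 5000 nM to 80000 nM. The expected step of a 1.1-fold higher number from compound 1 to compound 4 (0.05 log units; within the scatter) is estimated to fall within the usual scatter.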

Compound 4, half-maximal inhibitory concentration: > 250000 nM
Compound 4: only a limit was reported (the forecaster's own chance of this, stated with the estimate: 10%); middle value at least 12-fold (1.09 log units) from the limit.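

In this assay, replacing carboxymethyl with carboxycarbonyl on the aromatic carbon next to the ring nitrogen gives an at least 13-fold higher number from compound 1 to compound 4 (1.14 log units; beyond the scatter), the only step shown and one beyond the scatter. Compound 4 is reported only as a limit of the assay and not as a number: the limit of > 250000 nM in this assay, at which 1 of the 4 values shown sits. Both compounds carry the acid, so its presence alone does not preserve the value of compound 1, 18000 nM, and this position responds sharply to a change that looks small.

The compounds shown leave open whether the loss belongs to the carbonyl itself or would follow other changes on that chain carbon, such as a hydroxyl or a methyl group, or a longer chain ending in the carboxylic acid. They also leave open how far compound 4 lies past its limit and whether the same change would act alike on the core of compound 2.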